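One Added Methoxy on a Compound at the Limit

This account rests on a few compounds, and the source may have more. Where it says the series, first, only, none or still open, it means among the compounds named here.

Compound 1 `CN(C)c1ccc(/C=N/c2nnc[nH]2)cc1` gives > 30000 nM as a limit.
Compound 2 `Oc1ccccc1/C=N/n1cnnc1` gives > 30000 nM as a limit.
Compound 3 `Oc1ccc(/C=N/n2cnnc2)cc1` gives > 30000 nM as a limit.

These readings come from a functional assay on PC-3 cells (Homo sapiens) for cytotoxicity (on this read-out lower numbers stand for stronger inhibition and higher numbers for weaker inhibition), and none of them is an exact number. Compound 2 therefore has no precise place on the scale and stands with the other two compounds (the limit of > 30000 nM in this assay, at which 3 of the 3 values shown sit). The next compound, compound 4 `COc1cccc(/C=N/n2cnnc2)c1O`, differs from compound 2 in one place (methoxy in place of hydrogen on an aromatic carbon): methoxy in place of hydrogen on an aromatic carbon, ortho to a hydroxy group. Among the compounds with values here, no two measured compounds differ in one place, so the data give no direct size for such a change. The starting point is compound 2, whose limit is > 30000 nM and gives no sign of activity to build on. The expected change is none beyond the scatter, and the estimated size is a number no higher from compound 2 to compound 4 (the limit leaves the size open) in this assay and most likely another limit. The estimate for compound 4 is 30000 nM, with an expected range from 10000 nM to 80000 nM.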

Compound 4, half-maximal inhibitory concentration: > 30000 nM
Compound 4 gave a limit, no number (the forecaster's own chance of this, stated with the estimate: 75%); the middle value sits exactly at the limit.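

Compound 2 and compound 4 both give only a limit, not a number, so no step between them can be read: the limit of > 30000 nM in this assay, at which 4 of the 4 values shown sit.

The compounds shown leave open whether the added methoxy changes activity at all, and how far any of them lies from a measurable value.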